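Compound 2 to compound 3: a side-chain change

The source may hold more compounds than are shown below. What is called first, only, known or untested is meant among the compounds shown, and "the series" means these compounds.

Measured so far in a functional assay on MDA-MB-231 cells (Homo sapiens) for cytotoxicity, read by MTT assay, with a stated time of 72 h (a higher number here means a weaker inhibitor, a lower number a stronger inhibitor), as the test:
- compound 1 `O=C1c2c[n+]([O-])c3ccccc3c2C(=O)c2c1c1ccccc1n2Cc1cn(CC(O)CO)nn1` gives 1290 nM here
- compound 2 `O=C1c2c[n+]([O-])c3ccccc3c2C(=O)c2c1c1ccccc1n2CCN1CCCCC1` gives 1050 nM here

Compound 2 at 1050 nM sits within the scatter of compound 1 at 1290 nM in this pair, so neither value stands apart. Going by the values given here, compound 3 `CN1CCN(CCCCCn2c3c(c4ccccc42)C(=O)c2c[n+]([O-])c4ccccc4c2C3=O)CC1` keeps the shared core and carries 3-(4-methylpiperazin-1-yl)propyl in place of piperidin-1-yl on a saturated chain carbon, two bonds along the chain from an aromatic nitrogen as its one change from compound 2. Among the compounds with values here, the only measured step, a 1.2-fold lower number from compound 1 to compound 2 (0.09 log units; within the scatter), stayed within the scatter although it replaced a different side-chain group. Within the data shown here, no measured compound carries 3-(4-methylpiperazin-1-yl)propyl, so the data give no direction, and no step beyond the scatter is expected in this assay here. The expected step is a 1.1-fold lower number from compound 2 to compound 3 (0.04 log units; within the scatter) as an estimate. Compound 3 is expected at 950 nM, with an estimated range of 350 nM to 2600 nM for now.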

Compound 3, half-maximal inhibitory concentration: 2270 nM
Compound 3: the middle estimate sits 2.4-fold (0.38 log units) below what was measured; the measured number falls inside the stated range.
By their numbers in this assay, from the lowest: compounds 2, 1 and 3 (each within the scatter of the next, the first and the last beyond it).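

In this assay, the change from piperidin-1-yl to 3-(4-methylpiperazin-1-yl)propyl gives the first step beyond the scatter among these compounds, a 2.2-fold higher number from compound 2 to compound 3 (0.33 log units; beyond the scatter), though a modest one. This shows that the number can shift with the group on this saturated chain carbon, which the earlier step within the scatter did not show. Even so, a 1.8-fold higher number from compound 1 to compound 3 (0.25 log units; within the scatter) stays within the scatter, and nothing measured here accounts for the shift seen with compound 3.

The change alters the ring and the chain length together, so the compounds shown leave open which of the two goes with the step. A 2-(4-methylpiperazin-1-yl)ethyl group or a 5-(piperidin-1-yl)pentyl group on the aromatic nitrogen of the shared core would separate them.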